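Where a Phenol Follows a Methoxy Thioamide

The compounds below may be only part of what the source reports. "The series", "measured", "known", "first", "only" and "open" are said of these compounds alone.

Measured compounds:
- compound 1, `S=C(NCc1ccccc1)c1ccccc1`: 1900 nM
- compound 2, `COc1ccc(C(=S)NCc2ccccc2)cc1`: < 300 nM

Of the compounds shown here, two sharing one core have been tested in an ADME assay for pharmacokinetics, in phosphate buffer, with a stated time of 30 min, at pH 7.4, tested at 1 mM, at a dose of 1 mM, in the presence of a further agent that is not named here; a higher number here means more compound in the circulation at the dose given, a lower number less compound in the circulation. Compound 1, `S=C(NCc1ccccc1)c1ccccc1`, gives 1900 nM. For compound 2, `COc1ccc(C(=S)NCc2ccccc2)cc1`, the assay reports only a limit, < 300 nM, so the value shown is the edge of the assay and not a number. Among the measured compounds shown here, the one measured step runs downward: an at least 6.3-fold lower number from compound 1 to compound 2 (0.80 log units; beyond the scatter). Compound 2 therefore stands at the bottom of the shown numbers, at the limit of < 300 nM in this assay, at which 1 of the 2 values shown sits.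

Compound 3, `Oc1ccc(C(=S)NCc2ccccc2)cc1`, differs from compound 2 by hydrogen in place of methyl on an oxygen on an aromatic ring. No measured step covers a change on the oxygen itself; the only step shown, from hydrogen to methoxy on the ring, sets the starting point of compound 2 but gives no direction for removing the methyl. The expectation for compound 3 is therefore wide: a step of a number no lower from compound 2 to compound 3 (the limit leaves the size open) is estimated, with no confident direction. Compound 3 is expected to give 300 nM in this assay, within 50 nM to 1500 nM.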

Compound 3, maximal plasma concentration: 1100 nM
Compound 3: middle estimate off by 3.7-fold (0.56 log units), on the low side; measured number inside the range.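

In this assay, hydroxy in place of methoxy gives an at least 3.6-fold higher number from compound 2 to compound 3 (0.56 log units; beyond the scatter), so across these compounds the low number goes with the methyl on the oxygen and not with the oxygen alone. Hydroxy in place of hydrogen on the aromatic carbon gives a 1.7-fold lower number from compound 1 to compound 3 (0.24 log units; within the scatter), which means that the ring can carry a hydroxy group without a change that can be told apart from the usual scatter of this measurement. As far as these compounds go, the true size of the step to compound 3 remains unknown, as compound 2 has a limit and not a number: the limit of < 300 nM in this assay, at which 1 of the 3 values shown sits.

From the compounds shown here alone, whether a longer chain on the same oxygen, such as ethoxy, would behave like methoxy or give a number closer to that of compound 3 remains open. Also open, going by these compounds, is whether an amine or a carboxylic acid in place of the hydroxy group would stay level with compound 1 or fall away as compound 2 does, and these three compounds cannot say why the methyl matters.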